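The source may hold more compounds than are shown below. What is called first, only, known or untested is meant among the compounds shown, and "the series" means these compounds.

Among the compounds with values here, compound 1 `COC(=O)N(C)CC#CCN1CCCC1` is the one compound of the set with a numerical result: in a functional assay on the whole organism for agonist activity, with Mus musculus as the target (a lower number here means that less compound is needed, a higher number that more compound is needed for the effect), compound 1 gives 5.5 mg/kg. Compound 2 `COC(=O)N(C)CC#CCn1cncc1C` shares the methyl carbamate part but carries a different core, and the difference between the two cores is not broken down here. In this assay compound 2 gives only a limit of the assay, > 100 mg/kg. Compound 3 `COC(=O)N(C)C(C)C#CCn1cncc1C` differs from compound 2 by methyl in place of hydrogen on a saturated chain carbon bound to an amide-type nitrogen and a triple-bonded carbon, and in this assay compound 3 likewise gives only a limit, > 100 mg/kg. The step that the two limits leave unreadable from compound 2 to compound 3 therefore cannot be sized, because both ends sit at the limit of > 100 mg/kg in this assay, at which 2 of the 3 values shown sit. Within the data shown here, compound 4 `CCOC(=O)N(C)CC#CCN1CCCC1` differs from compound 1 by methyl in place of hydrogen on a saturated chain carbon bound to an oxygen next to a carbonyl group; this is the same kind of change as the one from compound 2 to compound 3, but the place differs, the new methyl sitting on a saturated chain carbon bound to an oxygen next to a carbonyl group rather than on one bound to an amide-type nitrogen and a triple-bonded carbon. With no readable precedent, the step of a 1.5-fold higher number from compound 1 to compound 4 (0.16 log units; within the scatter) is expected to be small, resting only on the result of compound 1, 5.5 mg/kg. Compound 4 is thus estimated at 8 mg/kg, within 2 mg/kg to 40 mg/kg.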

Compound 4, dose for half-maximal effect: > 100 mg/kg
Compound 4: a limit, no number (the forecaster's own chance of this, stated with the estimate: 10%); middle value at least 12-fold (1.09 log units) away from the limit.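

In this assay the change from methoxycarbonyl to ethoxycarbonyl on the core of compound 1 gives an at least 18-fold higher number from compound 1 to compound 4 (1.25 log units; beyond the scatter) and is thus a large step on this core. Compound 4 gives > 100 mg/kg and this is a limit of the assay, not a number. Within the data shown here, this does not show whether the change carries from one core to another: the only methyl step on the core of compound 2 sits at another place, on a saturated chain carbon bound to an amide-type nitrogen and a triple-bonded carbon, and it cannot be read, because both of its ends sit at a limit: (the limit of > 100 mg/kg in this assay, at which 3 of the 4 values shown sit).

The compounds shown leave open how the core of compound 2 would respond to ethoxycarbonyl, and how the core of compound 1 would respond to a methyl on the chain carbon that carries the amide-type nitrogen. They also leave open whether a propoxycarbonyl group or an acetyl group in place of methoxycarbonyl would be tolerated on the core of compound 1.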